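Para Substituent Swap on a Shared Core: Ester for Methoxy

A few compounds are considered here, and "the series" means these few. Any claim that something is new, unique, unknown or untested is made for them only; others in the source may bear on it.

Compound 1 `Fc1ccc(-c2ccc3nc(-c4ccccc4)cn3c2)cc1`: 22800 nM
Compound 2 `Clc1ccc(-c2ccc3nc(-c4ccccc4)cn3c2)cc1`: 45800 nM
Compound 3 `COc1ccc(-c2ccc3nc(-c4ccccc4)cn3c2)cc1`: 17800 nM

In an assay for inhibition of Retinaldehyde dehydrogenase 3 (Homo sapiens), with a stated time of 5 min (a higher number here means a weaker inhibitor, a lower number a stronger inhibitor), compound 3 gives the lowest of the three numbers. Its nearest neighbour is compound 1, a 1.3-fold lower number from compound 1 to compound 3 (0.11 log units; within the scatter); the gap to compound 2 is wider, a 2.6-fold lower number from compound 2 to compound 3 (0.41 log units; beyond the scatter). Compound 4 `COC(=O)c1ccc(-c2ccc3nc(-c4ccccc4)cn3c2)cc1` carries methoxycarbonyl in place of methoxy on an aromatic carbon. Among the measured compounds shown here, no measured step exchanges methoxy for methoxycarbonyl, so the three steps among compounds 1, 2 and 3 bear only indirectly: a 2.0-fold higher number from compound 1 to compound 2 (0.30 log units; within the scatter) and a 1.3-fold lower number from compound 1 to compound 3 (0.11 log units; within the scatter) show that changes at this position have moved this assay little. A step within the scatter is therefore expected, a 1.4-fold higher number from compound 3 to compound 4 (0.15 log units; within the scatter). Compound 4 is estimated at 25000 nM, with a range from 8000 nM to 80000 nM.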

Compound 4, half-maximal inhibitory concentration: 27400 nM
Beside the measured number, compound 4's estimate is 1.1-fold (0.04 log units) below it; low and high end bracket the measured number.
By their numbers in this assay, from the lowest: compounds 3, 1, 4 and 2 (each within the scatter of the next, the first and the last beyond it).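

Among the compounds shown here, the steps in this assay are a 1.5-fold higher number from compound 3 to compound 4 (0.19 log units; within the scatter) and a 1.7-fold lower number from compound 2 to compound 4 (0.22 log units; within the scatter) and a 1.2-fold higher number from compound 1 to compound 4 (0.08 log units; within the scatter) and so methoxycarbonyl, the first group here with a double bond outside aromatic rings, stands within the scatter of all three earlier groups. On this aromatic carbon, para to a large group, the exchange of methoxy for this larger ester therefore leaves the number in this assay unresolved from that of compound 3. No supporting measurement is available to explain this result.

On these data alone, whether a carboxylic acid or an amine here would also stay within the scatter remains open. So does whether changes elsewhere on the shared core would move this assay further.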